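The source may hold more compounds than are shown below. What is called first, only, known or untested is meant among the compounds shown, and "the series" means these compounds.

Measured compounds:
- compound 1, `NC(=O)CC[C@H](N)C(=O)NS(=O)(=O)OC[C@H]1O[C@@H](n2cnc3c(N)ncnc32)[C@H](O)[C@@H]1O`: 800 nM
- compound 2, `N=C(N)NCCC[C@H](N)C(=O)NS(=O)(=O)OC[C@H]1OC[C@@H](n2cnc3c(N)ncnc32)[C@H](O)[C@@H]1O`: 600 nM

In a functional assay on PBMC cells (Homo sapiens) for inhibition (on this read-out higher numbers stand for weaker inhibition and lower numbers for stronger inhibition), compound 1 gives the higher of the two numbers, but compound 2 lies within the scatter of it, so no order can be read between them. Compound 3, `CCC[C@H](N)C(=O)NS(=O)(=O)OC[C@H]1O[C@@H](n2cnc3c(N)ncnc32)[C@H](O)[C@@H]1O`, is not yet measured. It differs from compound 1 by methyl in place of carbamoyl on a saturated chain carbon, three bonds along the chain from an amine nitrogen and a carbonyl carbon. For the measured compounds named here, no measured pair shows this kind of change, so its size is not known from the data. The step from compound 1 to compound 3 is expected to weaken inhibition beyond the scatter, a 3.1-fold higher number from compound 1 to compound 3 (0.49 log units; beyond the scatter). Compound 3 is estimated at 2500 nM, in the range 800 nM to 8000 nM.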

Compound 3, half-maximal inhibitory concentration: 4700 nM
Estimate against measurement, compound 3: 1.9-fold (0.27 log units) below; low and high end bracket the measured number.
By their numbers in this assay, from the lowest: compounds 2 and 1 (each within the scatter of the next); then compound 3.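

In this assay, methyl in place of carbamoyl on this saturated chain carbon gives a 5.9-fold higher number from compound 1 to compound 3 (0.77 log units; beyond the scatter), so this position is sensitive to the change and the side chain does not merely fill space without consequence. Cut one bond further out, the same difference reads 2-carbamoylethyl to propyl, and the propyl chain gives the weaker inhibition. No measurement at hand bears on the reason for this step.

As far as these compounds go, whether the carbamoyl itself is needed remains open. A carboxylic acid, an amine or a longer chain at this position could each test that.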